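A few compounds are considered here, and "the series" means these few. Any claim that something is new, unique, unknown or untested is made for them only; others in the source may bear on it.

Three close analogues sharing one core have been measured in a functional assay on MDA-MB-231 cells (Homo sapiens) for inhibition, read by sulforhodamine B assay, tested at 10 uM; on this read-out lower numbers stand for less inhibition and higher numbers for more inhibition at the one concentration tested (going by the name of the read-out). Compound 1 `CN1CCN(c2ccc(C3=NNC(c4ccc(N(C)C)cc4)C3)cc2)CC1` carries a hydrogen on the ring nitrogen of the core and gives 11.4%. Compound 2 `CC(=O)N1N=C(c2ccc(N3CCN(C)CC3)cc2)CC1c1ccc(N(C)C)cc1` carries an acetyl on that nitrogen and gives -1%. Compound 3 `CN1CCN(c2ccc(C3=NN(S(=O)(=O)C4CC4)C(c4ccc(N(C)C)cc4)C3)cc2)CC1` carries a cyclopropylsulfonyl there and gives 3.7%. All three numbers sit close to zero, meaning little inhibition at the single concentration tested. The steps between them are small: a number 12.4 percentage points lower from compound 1 to compound 2 (beyond the scatter) and a number 7.7 percentage points lower from compound 1 to compound 3 (within the scatter). Compound 3 thus lies within the scatter of both other compounds, and the data support no ordering among the three.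

Compound 4 `Cc1ccc(S(=O)(=O)N2N=C(c3ccc(N4CCN(C)CC4)cc3)CC2c2ccc(N(C)C)cc2)cc1` keeps the sulfonyl on the ring nitrogen but alters what sits on its sulfur: 4-methylphenyl in place of cyclopropyl on a sulfonyl sulfur. For the measured compounds named here, no measured step changes the group on the sulfonyl sulfur, so the guidance is indirect. The exchange of acetyl for cyclopropylsulfonyl on the ring nitrogen gave a number 4.7 percentage points higher from compound 2 to compound 3 (within the scatter), and replacing the hydrogen of compound 1 by either group left the number low. Nothing here points to a move beyond the scatter, so compound 4 is expected to stay at a similar low level, a step of a number 0.3 percentage points higher from compound 3 to compound 4 (within the scatter). The estimate for compound 4 in this assay is 4%, with a range from -8% to 16%.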

Compound 4, a percentage reported as inhibition, at one concentration (the size of the read-out at that concentration, not a potency): 10.7%
Compound 4: middle estimate off by 6.7 percentage points, on the low side; measured number inside the range.
By their numbers in this assay, from the lowest: compounds 2, 3, 4 and 1 (each within the scatter of the next, the first and the last beyond it).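

Changing the group on the sulfonyl sulfur from cyclopropyl to the larger 4-methylphenyl gives a number 7 percentage points higher from compound 3 to compound 4 (within the scatter) in this assay and so leaves no difference that can be told from the usual scatter. Setting the sulfonyl compound against the acetyl compound gives a number 11.7 percentage points higher from compound 2 to compound 4 (beyond the scatter) as a modest step, the first one beyond the scatter that links a sulfonyl compound to the acetyl compound, while setting it against the compound with hydrogen on the ring nitrogen gives a number 0.7 percentage points lower from compound 1 to compound 4 (within the scatter) and shows that a 4-methylphenyl sulfonyl group on that nitrogen can sit level with hydrogen. No measurement is at hand that would explain these small differences.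

Going by these compounds, every number so far is low and comes from a single concentration, so it remains open whether any group on the sulfonyl sulfur can lift this read-out well clear of the scatter. A plain methyl, a longer chain, or a phenyl ring carrying an amine or a carboxylic acid in that place would test how far this result extends.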